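Dimethylphenyl for chlorohydroxyphenyl on the amide side chain

This account rests on a few compounds, and the source may have more. Where it says the series, first, only, none or still open, it means among the compounds named here.

Measured so far:
compound 1 `CC(C)C[C@H](N)c1cc(C(F)(F)F)ccc1N1CCN(C(=O)C(C)Cc2ccc(Cl)cc2O)CC1`: 36 nM
compound 2 `COc1cc(Cl)ccc1CC(C)C(=O)N1CCN(c2ccc(Cl)cc2[C@@H](N)CC(C)C)CC1`: 9.1 nM

In an assay on HEK293 cells for displacement of a labelled ligand from Melanocortin receptor 4 (Homo sapiens) (a lower number here means a stronger inhibitor, a higher number a weaker inhibitor), compound 1 gives 36 nM, the higher of the two numbers recorded. Among the compounds with values here, compound 2 gives 9.1 nM in this assay, and the gap between the two is beyond the usual scatter; the two compounds differ in more than one place, so no single step is drawn between them.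

Compound 3 `Cc1ccc(CC(C)C(=O)N2CCN(c3ccc(C(F)(F)F)cc3[C@@H](N)CC(C)C)CC2)cc1C` is not yet measured. It differs from compound 1 in one place:
3,4-dimethylphenyl in place of 4-chloro-2-hydroxyphenyl on a saturated chain carbon, two bonds along the chain from a carbonyl carbon

Compound 3 is expected to sit near compound 1 in this assay, with a step of a 1.5-fold higher number from compound 1 to compound 3 (0.18 log units; within the scatter) toward a higher number that may not exceed the scatter. The estimate for compound 3 is 55 nM, ranging from 15 nM to 220 nM.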

Compound 3, inhibition constant: 240 nM
Compound 3: middle estimate off by 4.4-fold (0.64 log units), on the low side; measured number above the stated range.
By their numbers in this assay, from the lowest: compound 2; then compound 1; then compound 3.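

In this assay, 3,4-dimethylphenyl in place of 4-chloro-2-hydroxyphenyl gives a 6.7-fold higher number from compound 1 to compound 3 (0.82 log units; beyond the scatter), so this position on the saturated chain carbon does not tolerate the swap without loss. The heavy-atom count stays the same, while the hydrogen-bond donor, the hydrogen-bond acceptor and the chlorine all leave in one step. No measurement shown here bears on the reason for this rise. Which departing feature matters remains open; a 4-chlorophenyl group and a 2-hydroxyphenyl group at this place would separate the chlorine from the hydroxyl.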